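Swapping the Spirocyclic Amine for a Methylpiperazine

The compounds below may be only part of what the source reports. "The series", "measured", "known", "first", "only" and "open" are said of these compounds alone.

Compound 1 `CN1CC2(C1)CN(c1ccc(OCc3ccccc3)c(C(=O)Nc3ccnnc3)c1)C2` stands second highest of the three numbers measured in a physicochemical assay for solubility, measured as kinetic solubility; on this read-out lower numbers stand for lower solubility and higher numbers for higher solubility; in this assay compound 1 gives 198000 nM. Compound 2 `O=C(Nc1ccnnc1)c1cc(N2CCC(CO)CC2)ccc1OCc1ccccc1` gives 323000 nM, while compound 3 `O=C(Nc1ccnnc1)c1cc(N2CCC(O)CC2)ccc1OCc1ccccc1` gives 28000 nM. The unmeasured compound 4 `CN1CCN(c2ccc(OCc3ccccc3)c(C(=O)Nc3ccnnc3)c2)CC1` differs from compound 1 in a single place: a group of 7 heavy atoms (5 carbon, 2 nitrogen; one six-membered non-aromatic ring with 2 hetero atoms) in place of a group of 8 heavy atoms (6 carbon, 2 nitrogen; 2 four-membered non-aromatic rings with 1 hetero atom each), on an aromatic carbon. Going by the values given here, two measured steps bear on this kind of swap, since each also puts a six-membered ring in place of the same group: a 1.6-fold higher number from compound 1 to compound 2 (0.21 log units; within the scatter) and a 7.1-fold lower number from compound 1 to compound 3 (0.85 log units; beyond the scatter). One of these lay within the scatter and the other was a modest drop, so for compound 4 a step of at most modest size is expected, in either direction. The number for compound 4 is estimated at 200000 nM, with a range from 60000 nM to 500000 nM, which means an expected step of a 1.0-fold higher number from compound 1 to compound 4 (0.00 log units; within the scatter).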

Compound 4, solubility: 228000 nM
The estimate for compound 4 lay 1.1-fold (0.06 log units) below the measured number; low and high end bracket the measured number.
By their numbers in this assay, from the lowest: compound 3; then compounds 1, 4 and 2 (each within the scatter of the next).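

At this aromatic carbon in this assay, 4-methylpiperazin-1-yl gives a 1.2-fold higher number from compound 1 to compound 4 (0.06 log units; within the scatter) in place of the group with two four-membered rings, so a single six-membered ring serves as well there. Set against 4-(hydroxymethyl)piperidin-1-yl, it gives a 1.4-fold lower number from compound 2 to compound 4 (0.15 log units; within the scatter) and the two stay level. Set against 4-hydroxypiperidin-1-yl, it gives an 8.1-fold higher number from compound 3 to compound 4 (0.91 log units; beyond the scatter) and compound 3 remains alone at the low end.

Nothing measured here explains why compound 3 stands apart. On these data alone, whether a carboxylic acid or a primary amine on the six-membered ring would keep the number this high remains open.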